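The compounds below may be only part of what the source reports. "The series", "measured", "known", "first", "only" and "open" are said of these compounds alone.

Compound 1 `CO[C@@H]1[C@@H](O)[C@@H](O)[C@H]2O[C@]1(C)n1c3ccccc3c3c4c(c5c6ccccc6n2c5c31)C(=O)NC4`: 1010 nM in an assay on isolated protein for inhibition of protein kinase C theta type (Homo sapiens), read by HTRF; a lower number here means a stronger inhibitor, a higher number a weaker inhibitor
Compound 2 `CO[C@@H]1[C@H](N(C)C=O)C[C@H]2O[C@]1(C)n1c3ccccc3c3c4c(c5c6ccccc6n2c5c31)C(=O)NC4`: 250 nM
Compound 3 `CN[C@]1(C(=O)OC)C[C@H]2O[C@]1(C)n1c3ccccc3c3c4c(c5c6ccccc6n2c5c31)C(=O)NC4`: > 2500 nM, a limit of the assay rather than a number

Among the numbers in this assay compound 2 stands lowest; compound 1 gives 1010 nM, a gap beyond the usual scatter. Compound 3 reaches only (the limit of > 2500 nM in this assay, at which 1 of the 3 values shown sits). Compound 4 `CO[C@@H]1[C@H](NC=O)C[C@H]2O[C@]1(C)n1c3ccccc3c3c4c(c5c6ccccc6n2c5c31)C(=O)NC4` differs from compound 2 by hydrogen in place of methyl on an amide-type nitrogen, the formyl(methyl)amino group becoming formylamino. For the measured compounds named here, no measured pair shares this change, so its size can only be expected: a shift within the usual scatter, in either direction, seems most likely. This estimate for compound 4 means a step of a 1.2-fold higher number from compound 2 to compound 4 (0.08 log units; within the scatter). Compound 4 is expected to give 300 nM, within a range from 120 nM to 800 nM.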

Compound 4, half-maximal inhibitory concentration: > 2500 nM
Compound 4 was reported as a limit (the forecaster's own chance of this, stated with the estimate: 5%); at least 8.3-fold (0.92 log units) between middle value and limit.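

In this assay, the methyl on this amide-type nitrogen proves far from incidental: hydrogen in its place gives an at least 10-fold higher number from compound 2 to compound 4 (1.00 log units; beyond the scatter). For the compounds shown here, this is the first pair differing in one place, and it shows that a single methyl at this position can separate a measurable inhibitor from an inactive-looking one. Compound 4 stands at a limit of the assay, not at a number: the limit of > 2500 nM in this assay, at which 2 of the 4 values shown sit.

Going by these compounds, the full size of the step therefore stays unknown. On these data alone, whether an ethyl group on this nitrogen, or an acetyl group in place of the formyl, would hold the level of compound 2 remains open.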